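The source may hold more compounds than are shown below. What is called first, only, known or untested is meant among the compounds shown, and "the series" means these compounds.

Compound 2 `CSC(=S)N1CCN(C(=S)SC(=S)N(C)C)CC1` carries methylsulfanyl on its thiocarbonyl carbon; in an ADME assay on HeLa cells (Homo sapiens) for cytotoxicity, read by MTT assay, with a stated time of 24 h (a higher number here means a weaker inhibitor, a lower number a stronger inhibitor), compound 2 reaches only the assay limit of > 5000000 nM, so no number is fixed for it (the limit of > 5000000 nM in this assay, at which 1 of the 2 values shown sits). Among the compounds with values here, compound 1 `CN(C)C(=S)SC(=S)N1CCN(C(=O)c2ccco2)CC1` gives 2380000 nM in this assay, and the single measured step, an at least 2.1-fold higher number from compound 1 to compound 2 (0.32 log units; beyond the scatter), sits on the amine nitrogen in the ring, not where compound 3 changes. Compound 3 `CN(C)C(=S)SC(=S)N1CCN(C(=S)NCc2ccccc2)CC1` differs from compound 2 by benzylamino in place of methylsulfanyl on a thiocarbonyl carbon. Within the data shown here, no measured step covers this change, so a step of an at least 1.6-fold lower number from compound 2 to compound 3 (0.22 log units; that floor lies within the scatter) is expected, staying weak. Compound 3 is estimated at 3000000 nM, range 1000000 nM to 10000000 nM.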

Compound 3, half-maximal inhibitory concentration: > 5000000 nM
Compound 3 was reported as a limit; the forecaster's own chance of this, stated with the estimate: 40%; middle value at least 1.6-fold (0.22 log units) from the limit.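

Compound 2 and compound 3 are both reported as limits in this assay, so no step can be read from one to the other: the limit of > 5000000 nM in this assay, at which 2 of the 3 values shown sit.

As far as these compounds go, the effect of benzylamino in place of methylsulfanyl on a thiocarbonyl carbon remains open, as does the actual cytotoxicity of either compound.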